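Carbamoyl to Methoxycarbonyl on a Shared Core

This account rests on a few compounds, and the source may have more. Where it says the series, first, only, none or still open, it means among the compounds named here.

Measured compounds:
compound 1 `NC(=O)c1nc(-c2ccccc2)n(-c2ccc(S(N)(=O)=O)cc2)n1`: 49%
compound 2 `NNC(=O)c1nc(-c2ccccc2)n(-c2ccc(S(N)(=O)=O)cc2)n1`: 45%

In a functional assay on the whole organism for inhibition, with Rattus norvegicus as the target, read by paw edema, with stated times of 30 min and 4 h, at a dose of 0.28 mmol/kg by the oral route (a higher number here means more inhibition at the dose given (going by the name of the read-out), a lower number less inhibition), compound 1 gives 49%, the higher of the two numbers shown. Compound 2 gives 45%, and the step of a number 4 percentage points lower from compound 1 to compound 2 (within the scatter) lies within the scatter, so the two values cannot be placed in an order. Compound 3 `COC(=O)c1nc(-c2ccccc2)n(-c2ccc(S(N)(=O)=O)cc2)n1` differs from compound 1 as follows: methoxy in place of amino on a carbonyl carbon. Within the data shown here, only one measured step exists, and it touches the same carbonyl end of the molecule, where amino in place of hydrogen on an amide-type nitrogen left the read-out essentially unchanged. Among the measured compounds shown here, no step here reaches beyond the scatter, so the expectation for the carbonyl change is a step of no clear direction. For compound 3 the estimated step is a number 4 percentage points lower from compound 1 to compound 3 (within the scatter). Compound 3 is therefore expected to give about 45%, within a range from 25% to 62%.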

Compound 3, a percentage reported as inhibition, in the whole organism at one dose (the size of the read-out at that dose, not a potency): 61%
Beside the measured number, compound 3's estimate is 16 percentage points below it; the range from low to high includes it.
By their numbers in this assay, from the lowest: compounds 2 and 1 (each within the scatter of the next); then compound 3.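

Among these compounds, at the carbonyl carbon of the shared core, this is the first change to move the read-out beyond the scatter in this assay: methoxy in place of amino gives a number 12 percentage points higher from compound 1 to compound 3 (beyond the scatter), and methoxy in place of aminoamino gives a number 16 percentage points higher from compound 2 to compound 3 (beyond the scatter). Among the compounds shown here, the position is therefore not indifferent to what the carbonyl carries, although the one earlier step there, a number 4 percentage points lower from compound 1 to compound 2 (within the scatter), alone gave no sign of this. Nothing available explains why the methoxycarbonyl compound stands apart from the two nitrogen-bearing groups.

The compounds shown leave open whether a longer chain such as ethoxy, or a free carboxylic acid, on the same carbonyl carbon would keep this level of inhibition. With the read-out taken at a single dose, they also leave open whether the step reflects a difference in potency.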